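The source may report more compounds than this note shows. Statements on the series, on what has been measured and on what is new or still open speak of the compounds shown alone.

The series shares a core seen in compound 1 `COC(c1cc(Cl)c2c(c1Cl)C(=O)N(Cc1c(C)cc(C)[nH]c1=O)CC2)C1CCN(C(C)=O)CC1`, which in a physicochemical assay for lipophilicity, at pH 7.4 (a lower number here means a more polar compound, a higher number a more lipophilic compound), gives compound 1 2.9; 2.9 (2 entries). Compound 2 `Cc1cc(C)c(CN2CCc3c(Cl)cc([C@@H](C)CO)c(Cl)c3C2=O)c(=O)[nH]1` gives compound 2 2.5 in this assay, the highest of the two single numbers in this set; its nearest neighbour, compound 3 `COc1cc(C)[nH]c(=O)c1CN1CCc2c(Cl)cc([C@H](O)C3COC3)c(Cl)c2C1=O`, gives compound 3 1.4, a gap beyond the scatter, while compound 1 contributes two entries rather than one number. Compound 4 `Cc1cc(C)c(CN2CCc3c(Cl)cc([C@H](CO)[C@@H]4CCCO4)c(Cl)c3C2=O)c(=O)[nH]1` remains to be measured. It differs from compound 2 by oxolan-2-yl in place of methyl on a saturated chain carbon bound to an aromatic carbon and a saturated chain carbon. Going by the values given here, no step between measured compounds isolates this change, so only a modest expectation is possible: a small rise, at most a little beyond the scatter, is expected from compound 2 to compound 4 of a number 0.20 log units higher from compound 2 to compound 4 (within the scatter). Compound 4 is therefore expected at 2.7, within 2.2 to 3.2.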

Compound 4, distribution coefficient: 2.4
The estimate for compound 4 lay 0.30 log units above the measured number; measured number inside the range.
By their numbers in this assay, from the lowest: compound 3; then compounds 4 and 2 (each within the scatter of the next).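

In this assay the step of a number 0.10 log units lower from compound 2 to compound 4 (within the scatter) comes with oxolan-2-yl in place of methyl on a saturated chain carbon bound to an aromatic carbon and a saturated chain carbon. Going by these compounds alone, this is the first single-place comparison in the set, and it shows that this position takes a five-membered non-aromatic ring bearing a hydrogen-bond acceptor with no change beyond the scatter. Nothing available gives a reason for this result.

Going by these compounds, it remains open whether an amine or a carboxylic acid at this place would also stay within the scatter of compound 2. On these data alone, the stereoisomer of compound 4 with the opposite configuration at the oxolan-2-yl stereocentre also remains open.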